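Trimethoxyphenyl Variation on the Benzyl Arm

This account rests on a few compounds, and the source may have more. Where it says the series, first, only, none or still open, it means among the compounds named here.

Of the compounds shown here, three sharing one core have been measured in a functional assay on MIA PaCa-2 cells (Homo sapiens) for antiproliferative activity, read by sulforhodamine B assay, with a stated time of 48 h; a higher number here means a weaker inhibitor of growth, a lower number a stronger inhibitor of growth. Compound 1 `COc1ccc(Cn2cc(CNC(=O)c3cn(-c4ccccc4)nc3-c3ccc(F)cc3)nn2)cc1` gives 3700 nM. Compound 2 `O=C(NCc1cn(Cc2ccc(Cl)cc2)nn1)c1cn(-c2ccccc2)nc1-c1ccc(Cl)cc1` gives 410 nM. Compound 3 `COc1ccc(Cn2cc(CNC(=O)c3cn(-c4ccccc4)nc3-c3ccc(Cl)cc3)nn2)cc1` gives 290 nM, the lowest of the three numbers; its gap to compound 2 is within the scatter, while the step of a 13-fold lower number from compound 1 to compound 3 (1.11 log units; beyond the scatter) is large and beyond the scatter.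

Compound 4 `COc1cc(Cn2cc(CNC(=O)c3cn(-c4ccccc4)nc3-c3ccc(Cl)cc3)nn2)cc(OC)c1OC` has not yet been measured. It differs from compound 3 in one place: 3,4,5-trimethoxyphenyl in place of 4-methoxyphenyl on a saturated chain carbon bound to an aromatic nitrogen. Within the data shown here, the one measured step that touches this same ring is a 1.4-fold lower number from compound 2 to compound 3 (0.15 log units; within the scatter), which lay within the scatter, so the number has so far been insensitive to what sits on that ring. The large step of a 13-fold lower number from compound 1 to compound 3 (1.11 log units; beyond the scatter) concerns a different ring and does not bear on this change.

Compound 4 is therefore expected to give about 250 nM in this assay, within a range from 80 nM to 800 nM. The expected step of a 1.2-fold lower number from compound 3 to compound 4 (0.06 log units; within the scatter) is no change beyond the scatter.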

Compound 4, concentration for 50% growth inhibition: 3500 nM
Beside the measured number, compound 4's estimate is 14-fold (1.15 log units) below it; measured number above the stated range.
By their numbers in this assay, from the lowest: compounds 3 and 2 (each within the scatter of the next); then compounds 4 and 1 (each within the scatter of the next).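

In this assay the group on a saturated chain carbon bound to an aromatic nitrogen turns out to matter: there is a 12-fold higher number from compound 3 to compound 4 (1.08 log units; beyond the scatter) and also an 8.5-fold higher number from compound 2 to compound 4 (0.93 log units; beyond the scatter), even though 4-chlorophenyl and 4-methoxyphenyl had stayed within the scatter of each other. The tolerance suggested by those two groups therefore does not extend to 3,4,5-trimethoxyphenyl, at least with chloro on the other aromatic ring. Nothing shown here accounts for this loss of growth inhibition.

The compounds shown leave open whether a plain phenyl, a pyridine ring or an amine at this place would keep the number of compound 3 or lose it as compound 4 does. They also leave open how 3,4,5-trimethoxyphenyl behaves with fluoro in place of chloro on the other ring.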